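Naphthalenyl in place of methoxyphenyl on a ring amide nitrogen

The source may report more compounds than this note shows. Statements on the series, on what has been measured and on what is new or still open speak of the compounds shown alone.

Three compounds share one core and have been measured:
compound 1, `CC(C)[C@@H]1CC[C@@H](C)C[C@@]12N(C)C(=O)[C@@H]1[C@H]3C(=O)N(C)C(=O)[C@H]3ON12`, gives 47.7%;
compound 2, `CC(C)[C@@H]1CC[C@@H](C)C[C@@]12N(C)C(=O)[C@@H]1[C@H]3C(=O)N(c4ccccc4)C(=O)[C@H]3ON12`, gives 35.4%;
compound 3, `COc1ccc(N2C(=O)[C@H]3[C@H](ON4[C@@H]3C(=O)N(C)[C@@]43C[C@H](C)CC[C@H]3C(C)C)C2=O)cc1`, gives 50%.

These numbers come from a functional assay, read by spectrophotometry, with a stated time of 2 h, tested at 1 mg/mL; a higher number here means a stronger effect of the compound at the concentration tested, a lower number a weaker effect. Compound 3 has the highest of the three numbers, but its value and that of compound 1 lie within the scatter of each other, so no order between them can be claimed; only compound 2 is clearly lower. The step from compound 1 to compound 3, a number 2.3 percentage points higher from compound 1 to compound 3 (within the scatter), shows that the aryl group in place of methyl made no clear difference. The step of a number 12.3 percentage points lower from compound 1 to compound 2 (beyond the scatter) and the step of a number 14.6 percentage points higher from compound 2 to compound 3 (beyond the scatter) together show that the aryl group without the methoxy gave a lower number than either of the other two.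

Compound 4, `CC(C)[C@@H]1CC[C@@H](C)C[C@@]12N(C)C(=O)[C@@H]1[C@H]3C(=O)N(c4ccc5ccccc5c4)C(=O)[C@H]3ON12`, has not yet been measured. It differs from compound 3 in one place: naphthalen-2-yl in place of 4-methoxyphenyl on an amide-type nitrogen in a ring. Like compound 2, it carries an aryl group on this nitrogen without a methoxy, and compound 2 gave the lowest number. Among the compounds with values here, on that basis a modest drop is expected, roughly the size of a number 14.6 percentage points higher from compound 2 to compound 3 (beyond the scatter) in reverse, though a second aromatic ring has no measured precedent here.

Compound 4 is therefore expected to give 38%, with a range from 24% to 52%, an estimated step of a number 12 percentage points lower from compound 3 to compound 4 (beyond the scatter).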

Compound 4, a percentage reported as activity, at one concentration (the size of the read-out at that concentration, not a potency): 29.6%
Compound 4: the middle estimate sits 8.4 percentage points above what was measured; low and high end bracket the measured number.
By their numbers in this assay, from the lowest: compounds 4 and 2 (each within the scatter of the next); then compounds 1 and 3 (each within the scatter of the next).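

In this assay, naphthalen-2-yl on the amide-type nitrogen in a ring gives a number 20.4 percentage points lower from compound 3 to compound 4 (beyond the scatter) when it replaces 4-methoxyphenyl and a number 18.1 percentage points lower from compound 1 to compound 4 (beyond the scatter) when it replaces methyl, so a larger aromatic group at this position does not match either of those two groups. When it replaces phenyl, the result is a number 5.8 percentage points lower from compound 2 to compound 4 (within the scatter): the second aromatic ring, new to this series, makes no clear difference from the single ring of compound 2. Among these four compounds, the two aryl groups without oxygen, phenyl and naphthalen-2-yl, therefore stand clearly apart from both methyl and 4-methoxyphenyl, and the only aryl group that stays level with methyl is the one carrying methoxy; no evidence is available to explain these differences.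

Going by these compounds, what remains open is whether the oxygen of the methoxy group matters in itself or whether any group at that spot on the phenyl ring would serve. A 4-hydroxyphenyl, 4-methylphenyl or 4-aminophenyl group on this nitrogen would test that, and a methoxy-bearing naphthalene would show whether the second ring still makes no clear difference once that group is present.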